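This account rests on a few compounds, and the source may have more. Where it says the series, first, only, none or still open, it means among the compounds named here.

Measured compounds in an assay on Sf9 cells for inhibition of serine/threonine-protein kinase 4 (Homo sapiens), read by luminescence and ADP-Glo, with a stated time of 1 h, in the presence of a further agent that is not named here; on this read-out lower numbers stand for stronger inhibition and higher numbers for weaker inhibition:

Compound 1 `CN1CC(=O)N(C)c2cnc(Nc3ccc(S(N)(=O)=O)cc3)nc21` — 495 nM
Compound 2 `CC(C)CC1C(=O)N(C)c2cnc(Nc3ccc(S(N)(=O)=O)cc3)nc2N1C` — 77 nM
Compound 3 `CN1C(=O)C(c2ccccc2)N(C)c2nc(Nc3ccc(S(N)(=O)=O)cc3)ncc21` — 383 nM

Compound 1 stands at the highest number of the three. Its nearest neighbour is compound 3, with a step of a 1.3-fold lower number from compound 1 to compound 3 (0.11 log units; within the scatter) that stays within the scatter; its furthest is compound 2, at a 6.4-fold lower number from compound 1 to compound 2 (0.81 log units; beyond the scatter), a modest step beyond the scatter. Between the two substituted analogues, the step of a 5.0-fold higher number from compound 2 to compound 3 (0.70 log units; beyond the scatter) is also beyond the scatter.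

Compound 4 `CN1C(=O)C(c2cccs2)N(C)c2nc(Nc3ccc(S(N)(=O)=O)cc3)ncc21` is the next analogue, not yet measured in this assay. It differs from compound 1 in one place: thiophen-2-yl in place of hydrogen on a saturated ring carbon. The step that bears most directly on it is the phenyl analogue, since thiophen-2-yl, like phenyl, is an aromatic ring placed on the same saturated ring carbon. That step, a 1.3-fold lower number from compound 1 to compound 3 (0.11 log units; within the scatter), did not leave the scatter. The isobutyl step, a 6.4-fold lower number from compound 1 to compound 2 (0.81 log units; beyond the scatter), was larger, but isobutyl is a saturated chain and is the less comparable reference. On this basis the expected step from compound 1 to compound 4 in this assay is a 1.4-fold lower number from compound 1 to compound 4 (0.15 log units; within the scatter), a change not expected to exceed the scatter. Compound 4 is therefore estimated at 350 nM, with a range of 150 nM to 900 nM.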

Compound 4, half-maximal inhibitory concentration: 88 nM
Compound 4: the middle estimate sits 4.0-fold (0.60 log units) above what was measured; the whole stated range lies above it.
By their numbers in this assay, from the lowest: compounds 2 and 4 (each within the scatter of the next); then compounds 3 and 1 (each within the scatter of the next).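

In this assay, a ring on this saturated ring carbon can shift the number beyond the scatter, which the phenyl step alone did not show: thiophen-2-yl gives a 5.6-fold lower number from compound 1 to compound 4 (0.75 log units; beyond the scatter), and exchanging phenyl for thiophen-2-yl at the same carbon gives a 4.4-fold lower number from compound 3 to compound 4 (0.64 log units; beyond the scatter), so at this position the outcome depends on which aromatic ring is attached and not merely on the presence of one. The comparison with the saturated chain gives a 1.1-fold higher number from compound 2 to compound 4 (0.06 log units; within the scatter), which stays within the scatter, so a five-membered aromatic ring with one hetero atom and an isobutyl chain cannot be told apart here, although phenyl stands apart from both. No measurement on hand accounts for the difference between the thiophen-2-yl and phenyl compounds.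

The compounds shown leave open whether the gain extends to other five-membered rings, such as furan-2-yl or thiophen-3-yl, or to a benzyl group on the same carbon. They also leave open how an amine or a carboxylic acid at this position would compare with isobutyl and thiophen-2-yl.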